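The source may hold more compounds than are shown below. What is called first, only, known or untested is meant among the compounds shown, and "the series" means these compounds.

Working notes on the series. Compound 1, `Cc1cc(-n2cc(C(=O)Nc3cc(F)cc(F)c3)c(=O)c3ccc(N(C)C)nc32)ccc1OCCCCCCC[N+]12CCN(CC1)CC2`, is the reference point: in an assay on LX2 cells for inhibition of COL1A1 promoter (Homo sapiens), read by a luciferase reporter, with a stated time of 24 h, tested at 20 uM (on this read-out higher numbers stand for a stronger effect at the one concentration tested and lower numbers for a weaker effect), compound 1 gives 10.6%, and this is the only numerical read-out available for the set. Compound 2, `CN(C)c1ccc2c(=O)c(C(=O)Nc3cc(F)cc(F)c3)cn(-c3ccc(Cl)c(OCCCCCCC[n+]4ccccc4)c3)c2n1`, is recorded in this assay as "not active" (no number reported), with no number attached. Compound 3, `CC[N+]1(CCCCCCCOc2ccc(-n3cc(C(=O)Nc4cc(F)cc(F)c4)c(=O)c4ccc(N(C)C)nc43)c(F)c2)CCCCC1`, is likewise recorded in this assay as "not active" (no number reported), again without a number. Among the compounds with values here, no two measured compounds differ in a single place, so no measured step exists for calibration; compound 1 stands simply as the one compound with a quantified effect, and nothing in the data separates it from compound 2 or compound 3 beyond the fact that a number was obtained.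

The next compound, compound 4, `CC[N+]1(CCCCCCCOc2ccc(-n3cc(C(=O)Nc4cc(F)cc(F)c4)c(=O)c4ccc(N(C)C)nc43)cc2C)CCCC1`, differs from compound 1 as follows: a group of 7 heavy atoms (6 carbon, 1 nitrogen; one five-membered non-aromatic ring with 1 hetero atom) in place of a group of 8 heavy atoms (6 carbon, 2 nitrogen; 2 six-membered non-aromatic rings with 2 hetero atoms each), on a saturated chain carbon, seven bonds along the chain from an oxygen on an aromatic ring. The shared core, the anilide and the chain are retained.

With only compound 1 and its 10.6% to go on, the step of a number 1.6 percentage points lower from compound 1 to compound 4 (within the scatter) is expected to stay within the usual scatter, with no direction assigned. Compound 4 is therefore estimated at 9% in this assay, with an expected range from 0% to 22%. A report without any number, as seen twice in this set, remains a real possibility for compound 4.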

Compound 4, a percentage reported as inhibition, at one concentration (the size of the read-out at that concentration, not a potency): 44.7%
Compound 4: middle estimate off by 35.7 percentage points, on the low side; the measured number lies above the stated range.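

The position at the chain end, on a saturated chain carbon, seven bonds along the chain from an oxygen on an aromatic ring, proves sensitive to the group it carries: in this assay the exchange of the group with 2 six-membered non-aromatic rings for the group with one five-membered non-aromatic ring gives a number 34.1 percentage points higher from compound 1 to compound 4 (beyond the scatter) with the shared core, the anilide and the chain retained. Both groups have net charge +1, so this step arises with the net charge unchanged, while the count of hydrogen-bond acceptors goes from 1 in the leaving group to 0 in the entering group. Nothing measured here bears on why the step has this size.

Within the data shown here, compound 2 and compound 3 carry no number and differ from compound 4 in more than one place, so no step to either can be read. As far as these compounds go, it remains open whether a morpholine ring or a trimethylammonium group at the chain end, or a longer chain under the five-membered ring, would keep this level of effect in this assay or lose it.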